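Sulfanyl for Cyanoamino on a Shared Core

The source may hold more compounds than are shown below. What is called first, only, known or untested is meant among the compounds shown, and "the series" means these compounds.

Compound 3 `C/N=C(\NC#N)NCCCCn1nc(-c2ccccc2)ccc1=O` holds the lowest of the two numbers measured in a functional assay on the whole organism (stomach) with Rattus norvegicus as the target (a lower number here means that less compound is needed, a higher number that more compound is needed for the effect), where compound 3 gives 32.4 mg/kg. Compound 2 `N#CNC(=N)NCCCCn1nc(-c2ccccc2)ccc1=O` gives 77.2 mg/kg in this assay, and the step of a 2.4-fold lower number from compound 2 to compound 3 (0.38 log units; beyond the scatter) separates the two. Compound 1 `C/N=C(\S)NCCCCn1nc(C)ccc1=O` is reported in this assay only as a limit, > 100 mg/kg, not as a number.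

Compound 4 `C/N=C(\S)NCCCCn1nc(-c2ccccc2)ccc1=O` has not yet been measured in this assay. It differs from compound 3 in one place: sulfanyl in place of cyanoamino on a carbon with a double bond to nitrogen. Among the compounds with values here, no measured step covers this exchange; the one measured step, a 2.4-fold lower number from compound 2 to compound 3 (0.38 log units; beyond the scatter), concerns a different change on an amine nitrogen. Compound 1 carries the same sulfanyl group as compound 4 yet differs from it elsewhere, and its result is only a limit (the limit of > 100 mg/kg in this assay, at which 1 of the 3 values shown sits). Given that compound 1 sits at the limit of > 100 mg/kg in this assay, at which 1 of the 3 values shown sits, compound 4 is expected to show a higher number than compound 3, with a fair chance that only a limit is reported. The expected step of a 2.2-fold higher number from compound 3 to compound 4 (0.33 log units; beyond the scatter) is accordingly upward. Compound 4 is estimated at 70 mg/kg, between 25 mg/kg and 200 mg/kg.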

Compound 4, dose for half-maximal effect: 28.9 mg/kg
Compound 4: middle estimate off by 2.4-fold (0.38 log units), on the high side; the measured number falls inside the stated range.
By their numbers in this assay, from the lowest: compounds 4 and 3 (each within the scatter of the next); then compound 2. At a limit, above all of these: compound 1.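

In this assay, sulfanyl in place of cyanoamino on a carbon with a double bond to nitrogen gives a 1.1-fold lower number from compound 3 to compound 4 (0.05 log units; within the scatter), so the two groups cannot be told apart at this position on the shared core. The sulfanyl compound also stands clear of the compound with the smaller group on the amine nitrogen, with a 2.7-fold lower number from compound 2 to compound 4 (0.43 log units; beyond the scatter), a step in the same direction as a 2.4-fold lower number from compound 2 to compound 3 (0.38 log units; beyond the scatter). Phenyl in place of methyl on an aromatic carbon gives an at least 3.4-fold lower number from compound 1 to compound 4 (0.53 log units; beyond the scatter), a step that can be given only as a bound, as compound 1 is reported as a limit: the limit of > 100 mg/kg in this assay, at which 1 of the 4 values shown sits.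

The compounds shown leave open whether an amine or a methoxy group on that same carbon would read like sulfanyl and cyanoamino. They also leave open whether this equivalence would hold with a longer chain.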